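Replacing a Phenyl Group with Butyl: Expected Cytotoxicity

This account rests on a few compounds, and the source may have more. Where it says the series, first, only, none or still open, it means among the compounds named here.

This small series shares one core and differs only in the group attached to a five-membered aromatic ring with 1 sulfur. Compound 1 `CCc1csc(CN[C@@H]2C[C@H]3C[C@@H]([C@H]2C)C3(C)C)c1` and compound 2 `C[C@H]1[C@H](NCc2sccc2-c2ccccc2)C[C@H]2C[C@@H]1C2(C)C` have both been run in an ADME assay on MDCK cells (Canis lupus familiaris) for cytotoxicity, read by microscopy, with a stated time of 48 h; on this read-out higher numbers stand for lower toxicity in this test and lower numbers for higher toxicity in this test. In this assay compound 1 gives 25000 nM, and compound 2 gives 12500 nM. For the measured compounds named here, compound 2 thus holds the lowest of the two numbers so far, but compound 1 is its nearest neighbour and the gap between them falls within the usual scatter, so the two cannot be told apart on this read-out.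

Compound 3 `CCCCc1ccsc1CN[C@@H]1C[C@H]2C[C@@H]([C@H]1C)C2(C)C` has not yet been measured. Against compound 2 it changes in one place: butyl in place of phenyl on an aromatic carbon.

Going by the values given here, no measured pair of compounds shows this kind of change, so the size of the step has to be inferred. Compound 1, which likewise carries no phenyl at that position, gives 25000 nM, and that number sits within the scatter of compound 2. The step of a 2.0-fold higher number from compound 2 to compound 3 (0.30 log units; within the scatter) is therefore expected to stay within the scatter, with no clear direction. Compound 3 is estimated at 25000 nM, with a range from 12500 nM to 50000 nM.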

Compound 3, minimum cytotoxic concentration: 25000 nM
Estimate against measurement, compound 3: no gap at the digits printed; the range from low to high includes it.
By their numbers in this assay, from the lowest: compounds 2, 1 and 3 (each within the scatter of the next).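

In this assay, for the compounds shown here, the swap of phenyl for butyl on an aromatic carbon of the five-membered aromatic ring with 1 sulfur now has a measured size, a 2.0-fold higher number from compound 2 to compound 3 (0.30 log units; within the scatter), and it is the first one-place step. At this position, then, a six-membered aromatic ring of carbon only and an open butyl chain with no ring cannot be told apart on this read-out, even though the two groups differ in shape and in heavy-atom count. This holds for this one pair and this one read-out, and no separate data are at hand that would explain the result.

Both groups compared here contain only carbon, so the compounds shown leave open whether a group with other atoms at this place, such as an amine or a carboxylic acid, would give a number beyond the scatter. They also leave open whether a longer chain than butyl, or a phenyl bearing a fluorine, would stay as close to compound 2 as butyl does.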